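The compounds below may be only part of what the source reports. "The series", "measured", "known", "first", "only" and "open" are said of these compounds alone.

Measured compounds:
- compound 1 `COc1cc2nncc(-c3cnc(N4CCC(C)(O)CC4)c(C)c3)c2cc1OC`: 35.8 mL/min/kg
- compound 2 `COC[C@H](C)Nc1ccc(-c2cnnc3cc(OC)c(OC)cc23)cn1`: 92.2 mL/min/kg

Both compounds were tested in an in vivo ADME assay on the whole organism for pharmacokinetics, with Rattus norvegicus as the target, at a dose of 1 mg/kg by the intravenous route; on this read-out lower numbers stand for slow clearance and higher numbers for fast clearance. Compound 1 gives 35.8 mL/min/kg, the lower of the two numbers, and compound 2 gives 92.2 mL/min/kg, a gap beyond the usual scatter. Among the measured compounds shown here, the two structures differ in several places at once, so the numbers show only that compound 1 is cleared more slowly; no single change can be read from them.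

Compound 3 `COc1cc2nncc(-c3cnc(N4CCC(O)(C5CC5)CC4)c(C)c3)c2cc1OC` has not yet been measured in this assay. It differs from compound 1 in one place: cyclopropyl in place of methyl on a saturated ring carbon. For the measured compounds named here, no measured pair shows what such a change does to clearance here, so the expectation rests on compound 1 alone. The step from compound 1 is expected to be small, most likely within the scatter, a 1.3-fold higher number from compound 1 to compound 3 (0.10 log units; within the scatter). Compound 3 is expected to give 45 mL/min/kg, with a range from 20 mL/min/kg to 100 mL/min/kg.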

Compound 3, clearance: 14.3 mL/min/kg
Compound 3: the middle estimate sits 3.1-fold (0.50 log units) above what was measured; the whole stated range lies above it.
By their numbers in this assay, from the lowest: compound 3; then compound 1; then compound 2.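

In this assay, among the compounds shown here, the swap of methyl for cyclopropyl on a saturated ring carbon, three ring bonds from the ring nitrogen, gives a 2.5-fold lower number from compound 1 to compound 3 (0.40 log units; beyond the scatter) and is the first single change that can be read. It shows that this position, which also carries the hydroxyl of the piperidine, is not indifferent to the group placed on it, and that a larger group here can go with slower clearance in the rat rather than faster. Nothing available explains why the number falls for this pair.

This one pair cannot separate the effect of the added carbons from that of the three-membered ring, which an open chain such as ethyl or isopropyl could help to tell apart. From the compounds shown here alone, whether a larger ring such as cyclobutyl, or a polar group such as an amine, would continue the same trend also stays open.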